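Removing One Fluorine from a Difluorophenyl Ring

This account rests on a few compounds, and the source may have more. Where it says the series, first, only, none or still open, it means among the compounds named here.

Measured so far:
compound 1, `O=C(Nc1ccc(F)c(-c2nc3ncc(-c4ccc(F)cc4F)cc3[nH]2)c1)N1CCCC1`: 15600 ng.h/mL
compound 2, `O=C(Nc1ccc(F)c(-c2nc3ncc(-c4cccc(F)c4F)cc3[nH]2)c1)N1CCCC1`: 4750 ng.h/mL

Of the compounds shown here, two have been measured in an ADME assay on the whole organism (Mus musculus, strain Swiss Webster) for pharmacokinetics, read by LC-MS, at a dose of 50 mg/kg by the oral route; on this read-out lower numbers stand for lower exposure and higher numbers for higher exposure at the dose given. Compound 1 gives 15600 ng.h/mL, and compound 2 gives 4750 ng.h/mL. Within the data shown here, compound 2 therefore stands lowest of the two numbers; its only neighbour is compound 1, and the step of a 3.3-fold lower number from compound 1 to compound 2 (0.52 log units; beyond the scatter) is beyond the scatter.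

The unmeasured compound 3, `O=C(Nc1ccc(F)c(-c2nc3ncc(-c4ccccc4F)cc3[nH]2)c1)N1CCCC1`, differs from compound 2 in one place: hydrogen in place of fluoro on an aromatic carbon. Cut one bond further out, the change reads 2,3-difluorophenyl to 2-fluorophenyl.

Among the measured compounds shown here, the one measured step, from compound 1 to compound 2, swapped the position of a fluoro group and lowered exposure; no measured step removes a fluoro group outright, so it bears only loosely on this change. A modest step in either direction in this assay seems plausible, with wide uncertainty. Compound 3 is therefore expected to give about 7000 ng.h/mL, within 2500 ng.h/mL to 20000 ng.h/mL, which means an expected step of a 1.5-fold higher number from compound 2 to compound 3 (0.17 log units; within the scatter).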

Compound 3, area under the concentration-time curve: 4870 ng.h/mL
For compound 3 the middle estimate is 1.4-fold (0.16 log units) above the measured one, and the stated range covers the measured number.
By their numbers in this assay, from the lowest: compounds 2 and 3 (each within the scatter of the next); then compound 1.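

Removing the fluoro group from the 2,3-difluorophenyl ring of compound 2 to leave the 2-fluorophenyl ring of compound 3 has no readable effect in this assay, with a 1.0-fold higher number from compound 2 to compound 3 (0.01 log units; within the scatter). The 2,4-difluorophenyl ring of compound 1 stands apart from that ring, with a 3.2-fold lower number from compound 1 to compound 3 (0.51 log units; beyond the scatter), so among these three compounds, the second fluoro group goes with a higher number only in the 2,4-difluorophenyl arrangement and not in the 2,3-difluorophenyl one. No supporting measurement is available to explain this difference.

Going by these compounds, it remains open whether a ring carrying chloro or methoxy in place of that second fluoro group would match 2,4-difluorophenyl or 2-fluorophenyl. On these data alone, how a plain phenyl ring with no fluoro group would compare also remains open.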